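Shortening the acid chain of a thromboxane receptor antagonist

The source may hold more compounds than are shown below. What is called first, only, known or untested is meant among the compounds shown, and "the series" means these compounds.

Measured compounds:
compound 1 `O=C(O)CCC/C=C\C[C@H]1[C@H](F)CC[C@@H]1NS(=O)(=O)c1ccccc1`: 1100 nM
compound 2 `O=C(O)CCC/C=C\C[C@H]1[C@H](F)CC[C@@H]1NS(=O)(=O)c1ccc(Cl)c(Cl)c1`: 630 nM
compound 3 `O=C(O)CCC/C=C\C[C@H]1[C@H](F)CC[C@@H]1NS(=O)(=O)c1ccccc1[N+](=O)[O-]`: 1800 nM

Three compounds share one core and differ only in the aryl group on the sulfonyl sulfur. In a functional assay on a cell-free system (plasma) for inhibition of thromboxane A2 receptor (Homo sapiens), read by turbidimetry (on this read-out lower numbers stand for stronger inhibition and higher numbers for weaker inhibition), compound 1 gives 1100 nM, the second highest of the three numbers. The step of a 1.7-fold lower number from compound 1 to compound 2 (0.24 log units; within the scatter) and the step of a 1.6-fold higher number from compound 1 to compound 3 (0.21 log units; within the scatter) both stay within the scatter, so compound 1 cannot be ordered against either neighbour. Within the data shown here, only the step of a 2.9-fold higher number from compound 2 to compound 3 (0.46 log units; beyond the scatter) is beyond the scatter.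

Compound 4 `O=C(O)CC/C=C\C[C@H]1[C@H](F)CC[C@@H]1NS(=O)(=O)c1ccccc1` changes a different part of the molecule: carboxy in place of carboxymethyl on a saturated chain carbon, two bonds along the chain from a double-bonded chain carbon. Among the measured compounds shown here, none of the measured steps touches this chain; all of them concern the aryl group, so no step bears on the present change and it cannot be read from the data. The expectation for compound 4 therefore rests on compound 1 alone, with a wide range. Compound 4 is expected to give 2000 nM in this assay, between 500 nM and 8000 nM, which would mean an estimated step of a 1.8-fold higher number from compound 1 to compound 4 (0.26 log units; within the scatter).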

Compound 4, half-maximal inhibitory concentration: 2000 nM
Compound 4: middle estimate and measured number agree at the digits printed; the measured number falls inside the stated range.
By their numbers in this assay, from the lowest: compounds 2, 1, 3 and 4 (each within the scatter of the next, the first and the last beyond it).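

In this assay the change from 5-carboxypent-1-en-1-yl to 4-carboxybut-1-en-1-yl, the first one made away from the aryl group, gives a 1.8-fold higher number from compound 1 to compound 4 (0.26 log units; within the scatter), so the two chain lengths cannot be told apart on this read-out. The earlier compounds shown here spoke only of the aryl group on the sulfonyl sulfur, whereas this pair shows that, with the phenyl group kept, the acid chain can be shortened at this position without a change that stands clear of the usual scatter of repeated measurements. No other measurement bears on this result, so the data offer no explanation for it.

Among these compounds, this single pair gives only one step along the chain, and it leaves open how a longer chain, a still shorter one, or a tetrazole or primary amide in place of the carboxylic acid would read in this assay. It also leaves open whether the same shortening would give a similar step with the 3,4-dichlorophenyl group of compound 2 or the 2-nitrophenyl group of compound 3.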